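Ring-fused dioxane replaces methoxyphenyl on an iminosugar chain

This account rests on a few compounds, and the source may have more. Where it says the series, first, only, none or still open, it means among the compounds named here.

Compound 2 `COc1ccc(-c2ccc(COCCCCCN3C[C@H](O)[C@@H](O)[C@H](O)[C@H]3CO)cc2)cc1` gives 10 nM in an assay on isolated protein for inhibition of Beta-glucosidase (Homo sapiens) (on this read-out higher numbers stand for weaker inhibition and lower numbers for stronger inhibition), level with compound 3 `OC[C@@H]1[C@@H](O)[C@H](O)[C@@H](O)CN1CCCCCOCc1ccc(-c2ccc(C(F)(F)F)cc2)cc1` at 10 nM, the two together the highest numbers of the three, while compound 1 `Cc1cccc(-c2ccc(COCCCCCN3C[C@H](O)[C@@H](O)[C@H](O)[C@H]3CO)cc2)c1` gives 2 nM. Compound 4 `OC[C@@H]1[C@@H](O)[C@H](O)[C@@H](O)CN1CCCCCOCc1ccc(-c2ccc3c(c2)OCCO3)cc1` carries 2,3-dihydro-1,4-benzodioxin-6-yl in place of 4-methoxyphenyl on an aromatic carbon. Within the data shown here, the steps that bear on this change are a 5.0-fold higher number from compound 1 to compound 2 (0.70 log units; beyond the scatter), a 5.0-fold higher number from compound 1 to compound 3 (0.70 log units; beyond the scatter) and no change at the digits printed from compound 2 to compound 3 (within the scatter); swapping one substituted phenyl for another at this end of the molecule moved the number modestly or not at all. The step from compound 2 to compound 4 is therefore expected to be small, no change at the digits printed from compound 2 to compound 4 (within the scatter), with no clear direction. Compound 4 is estimated at 10 nM, between 4 nM and 30 nM.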

Compound 4, half-maximal inhibitory concentration: 30 nM
For compound 4 the middle estimate is 3.0-fold (0.48 log units) below the measured one; the range from low to high includes it.
By their numbers in this assay, from the lowest: compound 1; then compounds 2 and 3 (each within the scatter of the next); then compound 4.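

Among these compounds, the fused dioxane ring separates a group from two that the earlier compounds could not tell apart: in this assay there is a 3.0-fold higher number from compound 2 to compound 4 (0.48 log units; beyond the scatter) and a 3.0-fold higher number from compound 3 to compound 4 (0.48 log units; beyond the scatter). The spread at this end of the molecule also widens, with a 15-fold higher number from compound 1 to compound 4 (1.18 log units; beyond the scatter), so the choice of aromatic group matters more here than the first three compounds showed. Nothing presented accounts for these steps. Going by these compounds, whether an open 3,4-dimethoxyphenyl group, with both oxygens kept but the ring undone, would stand with compound 2 or with compound 4 remains open.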